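This account rests on a few compounds, and the source may have more. Where it says the series, first, only, none or still open, it means among the compounds named here.

Compound 1 `CCc1cccc(NC(=O)C2Cc3cc(OC)c(OC)cc3C2=O)c1` and compound 2 `COc1cccc(NC(=O)C2Cc3cc(OC)c(OC)cc3C2=O)c1` share a core and differ in one group. In a physicochemical assay for lipophilicity, read by mass spectrometry (a lower number here means a more polar compound, a higher number a more lipophilic compound), compound 1 gives 3.11 and compound 2 gives 2.08, so compound 2 holds the lower of the two numbers. Compound 3 `CCOc1cccc(NC(=O)C2Cc3cc(OC)c(OC)cc3C2=O)c1` has not yet been measured. It differs from compound 2 by one small change, methyl in place of hydrogen on a saturated chain carbon bound to an oxygen on an aromatic ring, which turns methoxy into ethoxy. Among the measured compounds shown here, only one measured step bears on this, and only loosely: a number 1.03 log units lower from compound 1 to compound 2 (beyond the scatter), with methoxy in place of ethyl on an aromatic carbon. For the measured compounds named here, that is a different swap, and no measured pair shows the new change itself, so a modest rise, well short of that step, seems the reasonable expectation. The expected change is a number 0.42 log units higher from compound 2 to compound 3 (beyond the scatter). Compound 3 is therefore estimated at 2.5, with an expected range from 2.2 to 2.9.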

Compound 3, partition coefficient: 2.42
Compound 3: the middle estimate sits 0.08 log units above what was measured, and the stated range covers the measured number.
By their numbers in this assay, from the lowest: compound 2; then compound 3; then compound 1.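

In this assay, among the compounds shown here, methyl in place of hydrogen on a saturated chain carbon bound to an oxygen on an aromatic ring, which turns methoxy into ethoxy, gives a number 0.34 log units higher from compound 2 to compound 3 (beyond the scatter), the first direct reading of this change. The step of a number 0.69 log units lower from compound 1 to compound 3 (beyond the scatter) is smaller than the one seen with methoxy, a number 1.03 log units lower from compound 1 to compound 2 (beyond the scatter), so the added methyl closes part of that gap without removing it. Nothing available explains why the numbers move in this way.

On these data alone, whether the number keeps rising with a longer chain such as propoxy, or with a branched group such as isopropoxy, remains open. So does what an amine in this place would give, and whether the same step would appear on a different core.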